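This account rests on a few compounds, and the source may have more. Where it says the series, first, only, none or still open, it means among the compounds named here.

In a functional assay on A375P cells (Homo sapiens) for antiproliferative activity, read by MTT assay, with a stated time of 48 h (a lower number here means a stronger inhibitor, a higher number a weaker inhibitor), compound 1 `COc1cccc(-c2nc3sccn3c2-c2ccnc(NCCNC(=O)Nc3cc(C(F)(F)F)cc(C(F)(F)F)c3)n2)c1` gives 4300 nM. Compound 2 `O=C(NCCNc1nccc(-c2c(-c3cccc(O)c3)nc3sccn23)n1)Nc1ccccc1` is reported only at > 10000 nM, which is a limit of this assay and not a measured number. Compound 3 `COc1cccc(-c2nc3sccn3c2-c2ccnc(NCCNC(=O)Nc3ccccc3)n2)c1` differs from compound 2 by methyl in place of hydrogen on an oxygen on an aromatic ring. From the compounds shown here alone, since compound 2 stands at the limit of > 10000 nM in this assay, at which 1 of the 2 values shown sits, its true value is unknown, and the change to compound 3 is only a small substitution. The expected step is a step that the limit leaves unreadable from compound 2 to compound 3, nothing beyond the usual scatter. Compound 3 is therefore estimated at about 12000 nM, within a range from 4000 nM to 40000 nM, most likely again reported as a limit.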

Compound 3, half-maximal inhibitory concentration: > 10000 nM
Compound 3: no number, only a limit; the forecaster's own chance of this, stated with the estimate: 55%; the middle value lies beyond the limit too.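

Compound 2 and compound 3 are both reported only as limits of the assay, not as measured numbers, so no step between them can be read: the limit of > 10000 nM in this assay, at which 2 of the 3 values shown sit.

From the compounds shown here alone, how far changing 3-hydroxyphenyl to 3-methoxyphenyl shifts the true activity in this assay stays open.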